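The compounds below may be only part of what the source reports. "The series", "measured", "known", "first", "only" and "open" are said of these compounds alone.

Measured so far in an ADME assay on HeLa cells (Homo sapiens) for cytotoxicity, read by MTT assay; on this read-out higher numbers stand for weaker inhibition and lower numbers for stronger inhibition:
Compound 1 `N#Cc1c(-c2ccc(Cl)cc2)c(C#N)c(=O)n(/N=C/c2cn(-c3ccccc3)nc2-c2ccccc2)c1N` gives > 200 ug/mL, a limit of the assay.
Compound 2 `N#Cc1c(-c2ccccc2[N+](=O)[O-])c(C#N)c(=O)n(/N=C/c2cn(-c3ccccc3)nc2-c2ccccc2)c1N` gives > 200 ug/mL, a limit of the assay.
Compound 3 `N#Cc1c(-c2cccc([N+](=O)[O-])c2)c(C#N)c(=O)n(/N=C/c2cn(-c3ccccc3)nc2-c2ccccc2)c1N` gives > 200 ug/mL, a limit of the assay.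

Among the compounds with values here, compound 3 therefore stands at the limit shared by every value so far (the limit of > 200 ug/mL in this assay, at which 3 of the 3 values shown sit). The steps among the measured compounds, a step that the two limits leave unreadable from compound 1 to compound 2, a step that the two limits leave unreadable from compound 1 to compound 3 and a step that the two limits leave unreadable from compound 2 to compound 3, carry no readable size, so nothing about the effect of a change at this position can be taken from them.

Compound 4 `N#Cc1c(-c2ccc(C(F)(F)F)cc2)c(C#N)c(=O)n(/N=C/c2cn(-c3ccccc3)nc2-c2ccccc2)c1N` differs from compound 3 by 4-(trifluoromethyl)phenyl in place of 3-nitrophenyl on an aromatic carbon. With no readable step to draw on, the expectation is simply that compound 4 also sits at the limit in this assay. For compound 4 the expected value in this assay is 200 ug/mL, within a range of 100 ug/mL to 400 ug/mL. The expected step of a number no higher from compound 3 to compound 4 (the limit leaves the size open) is none beyond the scatter.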

Compound 4, half-maximal inhibitory concentration: > 200 ug/mL
Compound 4: only a limit was reported; the forecaster's own chance of this, stated with the estimate: 80%; the middle value lies on the limit itself.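

In this assay compound 4, like compounds 1, 2 and 3, gives only a limit, so no step among these compounds can be read: the limit of > 200 ug/mL in this assay, at which 4 of the 4 values shown sit.

The compounds shown leave open whether any change at this position shifts the read-out at all, and by how much.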